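Replacing the carbamate of compound 1 with a difluoropropyl amide

This account rests on a few compounds, and the source may have more. Where it says the series, first, only, none or still open, it means among the compounds named here.

Measured compounds in a functional assay on isolated protein for inhibition of Glucose-dependent insulinotropic receptor (Rattus norvegicus), read by HTRF and cAMP accumulation; a higher number here means a larger maximal response, a lower number a smaller maximal response:
Compound 1 `Cc1nc(S(C)(=O)=O)ccc1Oc1ncnc(OC2CCN(C(=O)OC(C)(C)C(F)(F)F)CC2)c1F`: 79%
Compound 2 `Cc1nc(S(C)(=O)=O)ccc1Oc1ncnc(OC2CCN(C(=O)OC(C)F)CC2)c1F`: 68%
Compound 3 `Cc1nc(S(C)(=O)=O)ccc1Oc1ncnc(OC2CCN(C(=O)OC3COC3)CC2)c1F`: 66%

Among these three, compound 1 stands highest; compound 2 comes nearest and compound 3 furthest, and both gaps lie beyond the scatter. The step of a number 11 percentage points lower from compound 1 to compound 2 (beyond the scatter) and the step of a number 13 percentage points lower from compound 1 to compound 3 (beyond the scatter) show that trading the 1-methyl-1-(trifluoromethyl)ethyl group for a smaller group on the oxygen next to the carbonyl costs a modest amount of maximal response in each case, whereas compound 2 and compound 3 differ only by a number 2 percentage points lower from compound 2 to compound 3 (within the scatter), which is within the scatter.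

Compound 4 `CCC(F)(F)C(=O)N1CCC(Oc2ncnc(Oc3ccc(S(C)(=O)=O)nc3C)c2F)CC1` has not been measured. It differs from compound 1 in this way:
1,1-difluoropropyl in place of 1-methyl-1-(trifluoromethyl)ethoxy on a carbonyl carbon
Both measured steps from compound 1 replace the same bulky fluorinated group with something smaller and both lower the response by a similar modest amount. Going by the values given here, the change to compound 4 also removes that group, and additionally removes the oxygen that carried it, so no measured step bears on it exactly; the closest guidance is that any departure from compound 1 so far has cost a modest amount. A drop of similar size is therefore expected for compound 4, giving a number 12 percentage points lower from compound 1 to compound 4 (beyond the scatter). Compound 4 is estimated at 67%, within a range from 54% to 80%.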

Compound 4, largest response reached (reported as efficacy), in percent of the reference or control that the assay uses: 90%
Estimate against measurement, compound 4: 23 percentage points below, and the stated range ends below it.
By their numbers in this assay, from the lowest: compounds 3 and 2 (each within the scatter of the next); then compound 1; then compound 4.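

In this assay the exchange on this carbonyl carbon gives a number 11 percentage points higher from compound 1 to compound 4 (beyond the scatter) and so shows that departing from the 1-methyl-1-(trifluoromethyl)ethoxy group need not lose response, since the 1,1-difluoropropyl group, with fewer heavy atoms and no oxygen, is the only replacement shown that goes above it. The same group also gives a number 24 percentage points higher from compound 3 to compound 4 (beyond the scatter) and a number 22 percentage points higher from compound 2 to compound 4 (beyond the scatter) and thus stands clear of both other replacements, so at this place, where the carbonyl carbon also carries the amide-type nitrogen in a ring, the group attached has a marked bearing on the maximal response, and compound 4 stands highest of the four. Nothing given here explains this rise in response.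

Compound 4 loses the oxygen and brings in the 1,1-difluoropropyl group in a single step, so the compounds shown leave open how much of the gain belongs to each of these changes. They also leave open whether a plain propyl chain, a cyclopropyl group or a longer difluoroalkyl chain on this carbonyl carbon would keep the response of compound 4.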